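Sulfonamide series: hexyl chain in place of the alkyne

The compounds below may be only part of what the source reports. "The series", "measured", "known", "first", "only" and "open" are said of these compounds alone.

Three compounds share one core and differ only on the aryl ring attached to the sulfonyl sulfur. Compound 1 `CC(=O)Nc1nc(-c2cccc(NS(=O)(=O)c3ccc(C#CC4CCCCC4)cc3)c2)cs1` gives 1.2% in a functional assay on A-375 cells (Homo sapiens) for antiproliferative activity, read by trypan blue exclusion, with a stated time of 48 h, tested at 5 uM; on this read-out higher numbers stand for a weaker effect at the one concentration tested and lower numbers for a stronger effect. Compound 2 `C#Cc1ccc(S(=O)(=O)Nc2cccc(-c3csc(NC(C)=O)n3)c2)cc1` gives 38.3% in this assay, the highest of the three numbers, that is, the weakest effect seen so far. Compound 3 `C#Cc1cccc(S(=O)(=O)Nc2cccc(-c3csc(NC(C)=O)n3)c2)c1` gives 29% in this assay. The step of a number 37.1 percentage points higher from compound 1 to compound 2 (beyond the scatter) is the only large one in the set; the step of a number 9.3 percentage points lower from compound 2 to compound 3 (within the scatter) stays within the scatter, so compound 2 and compound 3 cannot be ranked.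

Compound 4 `CCCCCCc1ccc(S(=O)(=O)Nc2cccc(-c3csc(NC(C)=O)n3)c2)cc1` is the next step from compound 2. The change is hexyl in place of ethynyl on an aromatic carbon. Going by the values given here, the one measured step that bears on it runs the other way: going from compound 1 to compound 2 removed a cyclohexyl from the triple-bonded carbon and raised the number by a large margin. Here the entering hexyl brings 6 heavy atoms where the ethynyl had 2, at the same place on the ring, para to a large group. The number for compound 4 in this assay is therefore expected to fall, by roughly a number 26.3 percentage points lower from compound 2 to compound 4 (beyond the scatter), because compound 1 with its larger group stands at 1.2%. The estimate for compound 4 is 12%, with a range from 1% to 35%.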

Compound 4, a percentage reported as activity, at one concentration (the size of the read-out at that concentration, not a potency): < 1%
Compound 4: a limit, no number; the forecaster's own chance of this, stated with the estimate: 0%; middle value at least 11 percentage points from the limit.
By their numbers in this assay, from the lowest: compound 1; then compounds 3 and 2 (each within the scatter of the next). At a limit, below all of these: compound 4.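

In this assay compound 4 gives < 1%, which is a limit of the assay and not a number: the limit of < 1% in this assay, at which 1 of the 4 values shown sits.

Hexyl in place of ethynyl on an aromatic carbon, para to a large group, gives a number at least 37.3 percentage points lower from compound 2 to compound 4 (beyond the scatter), so a large step at this place does not depend on a triple bond or a ring in the entering group, both of which compound 1 carries. The comparison of the two large groups gives a number at least 0.2 percentage points lower from compound 1 to compound 4 (that floor lies within the scatter), so hexyl and 2-cyclohexylethynyl cannot be ranked at this place, and the open-chain and the ring-bearing alkyne groups stand together at the low end of the read-out for now.

The compounds shown leave open how much chain this place needs, since a propyl or butyl chain would fall in the gap between ethynyl and hexyl, and an octyl chain would test the upper end. They also leave open whether a hexyl chain ending in an amine or a carboxylic acid keeps the low reading, and whether a hexyl chain at the ring place held by the ethynyl of compound 3 behaves the same way.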